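Removing one methoxy from a limit-bound sulfonyl enone

The compounds below may be only part of what the source reports. "The series", "measured", "known", "first", "only" and "open" are said of these compounds alone.

Compound 1 `COc1cc(OC)c(/C=C(\C(=O)c2ccc(Br)cc2)S(=O)(=O)c2ccc(Br)cc2)c(OC)c1` stands at the assay limit in a functional assay on DU-145 cells (Homo sapiens) for inhibition, read by trypan blue exclusion, with a stated time of 96 h; on this read-out lower numbers stand for stronger inhibition of growth and higher numbers for weaker inhibition of growth: compound 1 gives > 100000 nM, a limit rather than a number. Compound 2 `COc1cc(OC)c(/C=C(\C(=O)c2ccc(Br)cc2)S(=O)(=O)Cc2ccc(Cl)cc2)c(OC)c1` gives 25000 nM. Compound 3 `COc1cc(OC)c(/C=C(/Sc2ccc(C)cc2)C(=O)c2ccc(Br)cc2)c(OC)c1` also reaches a limit, > 100000 nM. Compound 4 `COc1ccc(/C=C(\C(=O)c2ccc(Br)cc2)S(=O)(=O)c2ccc(Br)cc2)c(OC)c1` differs from compound 1 only in hydrogen in place of methoxy on an aromatic carbon. The measured steps all concern the sulfonyl side of the core: an at least 4.0-fold lower number from compound 1 to compound 2 (0.60 log units; beyond the scatter), an at least 4.0-fold higher number from compound 2 to compound 3 (0.60 log units; beyond the scatter) and a step that the two limits leave unreadable from compound 1 to compound 3. For the measured compounds named here, none touches the methoxy pattern, so no measured step bears on this change, and compound 1 itself offers only a limit, here (the limit of > 100000 nM in this assay, at which 2 of the 3 values shown sit). Compound 4 is therefore expected to stay near that limit, estimated at 100000 nM with a range of 30000 nM to 300000 nM. The expected step is a number no higher from compound 1 to compound 4 (the limit leaves the size open).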

Compound 4, concentration for 50% growth inhibition: 8000 nM
The estimate for compound 4 lay 13-fold (1.10 log units) above the measured number, and the stated range ends above it.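

The methoxy pattern matters in this series: hydrogen in place of methoxy on an aromatic carbon, ortho to a large group, gives an at least 12-fold lower number from compound 1 to compound 4 (1.09 log units; beyond the scatter). This is the first change shown away from the sulfonyl side of the core, and it brings a limit-bound compound to a readable number. The true size of the step stays open, since the value of compound 1 is a limit: the limit of > 100000 nM in this assay, at which 2 of the 4 values shown sit.

As far as these compounds go, whether another group at this place, such as a hydroxyl or an amine, would match hydrogen remains open. So does whether removing this methoxy from compound 2 would give a similar step.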